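Swapping 4-fluorophenyl for 6-fluoropyridin-3-yl at the limit

This account rests on a few compounds, and the source may have more. Where it says the series, first, only, none or still open, it means among the compounds named here.

In an ADME assay on MRC5 cells (Homo sapiens) for cytotoxicity, read by fluorescence, with a stated time of 72 h (on this read-out lower numbers stand for stronger inhibition and higher numbers for weaker inhibition), compound 1 `CC1(COc2ccc(-c3ccc(F)cc3)cn2)Cn2cc([N+](=O)[O-])nc2O1` gives > 64000 nM as a limit of the assay and not a number. Compound 2 `CC1(COc2ccc(-c3ccc(OC(F)(F)F)cc3)cn2)Cn2cc([N+](=O)[O-])nc2O1` likewise gives > 64000 nM as a limit. The evidence so far is the limit of > 64000 nM in this assay, at which 2 of the 2 values shown sit, and nothing more. Among the compounds with values here, compound 3 `CC1(COc2ccc(-c3ccc(F)nc3)cn2)Cn2cc([N+](=O)[O-])nc2O1` carries 6-fluoropyridin-3-yl in place of 4-fluorophenyl on an aromatic carbon as its single change. Within the data shown here, the only measured step is a step that the two limits leave unreadable from compound 1 to compound 2 and gives no size for this change, so a number no higher from compound 1 to compound 3 (the limit leaves the size open) is the estimated step in this assay and nothing beyond the scatter is expected. Compound 3 is estimated at 64000 nM with an expected range from 30000 nM to 100000 nM and may again report only a limit.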

Compound 3, half-maximal inhibitory concentration in the MRC5 assay: > 64000 nM
Compound 3 ended at the assay's limit (the forecaster's own chance of this, stated with the estimate: 85%); the middle value sits exactly at the limit.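

In the MRC5 assay compound 1 gives > 64000 nM, a limit of the assay and not a number. In the MRC5 assay compound 3 gives > 64000 nM, likewise a limit of the assay and not a number. Within the data shown here, no step between these two compounds can be read: the limit of > 64000 nM in the MRC5 assay, at which 3 of the 3 values shown sit. In a physicochemical assay for solubility, read by HPLC, measured as kinetic solubility, at 20 degrees C, at pH 7 (on this read-out lower numbers stand for lower solubility and higher numbers for higher solubility), compound 1 gives 0.19 ug/mL and compound 3 gives 3.3 ug/mL. With 6-fluoropyridin-3-yl in place of 4-fluorophenyl, the physicochemical assay shows a 17-fold higher number from compound 1 to compound 3 (1.24 log units; beyond the scatter): the measured solubility of compound 1, 0.19 ug/mL, and of compound 3, 3.3 ug/mL, a 17-fold higher number (1.24 log units; beyond the scatter). The compounds shown leave open whether any change to the shared core would bring a measurable number in the MRC5 assay.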